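The compounds below may be only part of what the source reports. "The series", "measured", "known", "first", "only" and "open" are said of these compounds alone.

Of the compounds shown here, three built on one shared core have been measured in a functional assay on MGC-803 cells (Homo sapiens) for inhibition, read by MTT assay, with a stated time of 72 h; a higher number here means a weaker inhibitor, a lower number a stronger inhibitor. Compound 1 `O=C(CSc1nc(Nc2ccccc2)c2ccccc2n1)Nc1ccccc1Cl` gives 24800 nM. Compound 2 `O=C(CSc1nc(Nc2ccccc2)c2ccccc2n1)Nc1cccc(F)c1` gives 12700 nM in this assay, and compound 3 `O=C(CSc1nc(Nc2ccccc2)c2ccccc2n1)Nc1cccc(Cl)c1` gives 14300 nM. The three numbers sit close together: the steps of a 2.0-fold lower number from compound 1 to compound 2 (0.29 log units; within the scatter), a 1.7-fold lower number from compound 1 to compound 3 (0.24 log units; within the scatter) and a 1.1-fold higher number from compound 2 to compound 3 (0.05 log units; within the scatter) are all within the scatter, so compound 3 cannot be separated from either of the other two by more than the usual spread of repeated measurements.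

Compound 4 `O=C(CSc1nc(Nc2ccccc2)c2ccccc2n1)Nc1ccc(Br)cc1` has not yet been measured in this assay. It differs from compound 3 in one place: 4-bromophenyl in place of 3-chlorophenyl on an amide-type nitrogen. Going by the values given here, the steps that bear on this change are those that exchanged the same group on the amide-type nitrogen, namely a 1.7-fold lower number from compound 1 to compound 3 (0.24 log units; within the scatter) and a 1.1-fold higher number from compound 2 to compound 3 (0.05 log units; within the scatter), both within the scatter; no measured pair brings in bromine, so the present change has no direct precedent. The expectation is therefore a 1.0-fold lower number from compound 3 to compound 4 (0.01 log units; within the scatter), that is, nothing beyond the scatter in either direction. For compound 4 the estimate is 14000 nM, with a range from 6000 nM to 35000 nM.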

Compound 4, half-maximal inhibitory concentration: 19300 nM
Estimate against measurement, compound 4: 1.4-fold (0.14 log units) below, and the stated range covers the measured number.
By their numbers in this assay, from the lowest: compounds 2, 3, 4 and 1 (each within the scatter of the next).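

In this assay the 4-bromophenyl group on the amide-type nitrogen brings in bromine and a new ring placement, yet the number stays level with the others: the steps are a 1.3-fold higher number from compound 3 to compound 4 (0.13 log units; within the scatter) and a 1.5-fold higher number from compound 2 to compound 4 (0.18 log units; within the scatter) and a 1.3-fold lower number from compound 1 to compound 4 (0.11 log units; within the scatter) with none of them beyond the scatter. Across the four listed compounds, then, exchanging one halogen-bearing phenyl group for another at this position has shown no measurable effect, and no compound goes against this. Because this step changes the halogen and its ring placement together, it cannot separate the two.

Going by these compounds, whether an amine or a carboxylic acid on this phenyl ring, or a longer chain in its place, would move the number beyond the scatter remains open. Nothing measured here offers an explanation for these results.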